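Swapping the Aryl Group on a Shared Core

This account rests on a few compounds, and the source may have more. Where it says the series, first, only, none or still open, it means among the compounds named here.

Compound 1 `CCCCN(CC)c1cc(C)nc2c1NC(=O)CN2c1ccc(C(C)C)cc1Br`: 0.7%
Compound 2 `CCCCN(CC)c1cc(C)nc2c1NC(=O)CN2c1ccc(C(C)(C)C)cc1Br`: -3.8%
Compound 3 `CCCCN(CC)c1cc(C)nc2c1NC(=O)CN2c1ccc(OC)cc1C`: -2.3%

All three measured compounds share the same fused core and differ only in the aromatic group attached to its ring nitrogen. In an assay on HEK-293T cells for displacement of a labelled ligand from corticotropin-releasing factor receptor 2 (Homo sapiens), read by scintillation counting, with a stated time of 2 h, tested at 1 uM (on this read-out lower numbers stand for less inhibition and higher numbers for more inhibition at the one concentration tested (going by the name of the read-out)), compound 1 gives 0.7%, compound 2 gives -3.8% and compound 3 gives -2.3%. Every one of these numbers sits close to zero, and they lie within the usual scatter of one another, so none of them can be said to give a higher or lower number than the others. Compound 3 stands second highest of the three, but that ordering means nothing given the scatter.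

Compound 4 `CCCCN(CC)c1cc(C)nc2c1NC(=O)CN2c1ccc(Br)cc1CC` has not yet been measured. It differs from compound 3 in one place: 4-bromo-2-ethylphenyl in place of 4-methoxy-2-methylphenyl on a nitrogen on an aromatic ring in a ring. For the measured compounds named here, no measured step covers this exact exchange. Going by the values given here, the only step available, a number 4.5 percentage points lower from compound 1 to compound 2 (within the scatter), concerns a different change on a saturated chain carbon and stayed within the scatter. With every measured compound showing essentially no inhibition, no movement beyond the scatter is expected in this assay. The expected step is a number 2.3 percentage points higher from compound 3 to compound 4 (within the scatter). Compound 4 is therefore estimated at 0%, with a likely range from -10% to 10%.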

Compound 4, a percentage reported as inhibition, at one concentration (the size of the read-out at that concentration, not a potency): 2.1%
Compound 4: middle estimate off by 2.1 percentage points, on the low side, and the stated range covers the measured number.
By their numbers in this assay, from the lowest: compounds 2, 3, 1 and 4 (each within the scatter of the next).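

Unlike the earlier step, which touched only a saturated chain carbon, this exchange replaces the whole aromatic group on the ring nitrogen, and in this assay it gives a number 4.4 percentage points higher from compound 3 to compound 4 (within the scatter). The 4-methoxy-2-methylphenyl group that leaves has 1 hydrogen-bond acceptor and the 4-bromo-2-ethylphenyl group that enters has 0, with 9 heavy atoms in each, so two substituents on the ring can change together at this position without the read-out moving beyond the scatter. Nothing available explains why the numbers stay so close to zero or links them to a property of either group.

The compounds shown leave open whether a different kind of group on the ring nitrogen, such as a pyridine ring or a phenyl ring carrying an amine or a carboxylic acid, would give a number beyond the scatter. They also leave open whether a change elsewhere on the shared core, such as a longer chain on its amine nitrogen in place of the ethyl group, would do so.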